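This account rests on a few compounds, and the source may have more. Where it says the series, first, only, none or still open, it means among the compounds named here.

Measured so far in a functional assay on A549 cells (Homo sapiens) for cytotoxicity, read by MTT assay, with a stated time of 72 h; on this read-out lower numbers stand for stronger inhibition and higher numbers for weaker inhibition:
- compound 1 `Cc1ccc(C(=O)Nc2nnc(-c3ccc(O)c(O)c3)s2)cc1`: 11800 nM
- compound 2 `O=C(Nc1nnc(-c2cccc(O)c2O)s1)c1ccccc1`: 12300 nM

Both numbers are in the same range, and the gap between them lies within the usual scatter of repeated measurements. Compound 1 therefore stands level with compound 2, and neither can be ranked above the other. Compound 3 `O=C(Nc1nnc(-c2ccc(O)c(O)c2)s1)c1ccc(Cl)cc1` has not yet been measured in this assay.

Going from compound 1 to compound 3 changes a single place: chloro in place of methyl on an aromatic carbon. In words, this is chloro in place of methyl on an aromatic carbon, para to a large group, so 4-methylphenyl becomes 4-chlorophenyl. The rest of the molecule stays the same.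

For the measured compounds named here, neither measured pair shows this exchange on its own, so the data offer no direct precedent for it. With so little to go on, the safest expectation in this assay is no change beyond the scatter, in either direction. The expected step is a 1.1-fold lower number from compound 1 to compound 3 (0.03 log units; within the scatter). For compound 3 the estimated value is 11000 nM, with an expected range from 5000 nM to 24000 nM.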

Compound 3, half-maximal inhibitory concentration: 14600 nM
The estimate for compound 3 lay 1.3-fold (0.12 log units) below the measured number; measured number inside the range.
By their numbers in this assay, from the lowest: compounds 1, 2 and 3 (each within the scatter of the next).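

In this assay, for the compounds shown here, the exchange of methyl for chloro on the aromatic carbon, which turns 4-methylphenyl into 4-chlorophenyl, can now be read directly for the first time, and it gives a 1.2-fold higher number from compound 1 to compound 3 (0.09 log units; within the scatter) as its step. At this place, then, methyl and chloro cannot be told apart on the core of compound 1: a swap of one heavy atom for another leaves compound 1 and compound 3 level with each other, which the earlier comparison of compound 1 with compound 2 could not show, as those two differ in more than one place. Nothing measured here offers a reason for this level result.

From the compounds shown here alone, two single-atom groups on one core say little about how much this place tolerates, so it remains open whether an amine, a carboxylic acid or a longer chain at the same carbon would move the number beyond the scatter. Going by these compounds, it is also open whether the exchange of methyl for chloro would read the same with the two hydroxyl groups arranged as they are in compound 2.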